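The source may report more compounds than this note shows. Statements on the series, on what has been measured and on what is new or still open speak of the compounds shown alone.

Among the measured compounds shown here, compound 1, `CCN(Cc1cccs1)C(=O)COc1ccc(C)cc1`, is the stronger of the two compounds measured so far. In an assay on HEK293 cells for agonist activity at transient receptor potential cation channel subfamily M member 8 (Homo sapiens), read by fluorescence and calcium flux, with a stated time of 15 min (on this read-out lower numbers stand for an effect already at smaller amounts and higher numbers for an effect only at larger amounts of compound), compound 1 gives 8 nM, the lowest of the two numbers. For the measured compounds named here, its only measured neighbour, compound 2, `CCN(Cc1cccs1)C(=O)COc1ccc(Cl)cc1`, gives 39 nM in this assay, and the step between them, chloro in place of methyl on an aromatic carbon, is a 4.9-fold higher number from compound 1 to compound 2 (0.69 log units; beyond the scatter).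

Compound 3, `CCN(Cc1nccs1)C(=O)COc1ccc(C)cc1`, has not yet been measured. It differs from compound 1 at the other end of the shared core: 1,3-thiazol-2-yl in place of thiophen-2-yl on a saturated chain carbon bound to an amide-type nitrogen. Going by the values given here, no measured step touches that place; the one available step concerns a group on the aromatic ring far from the amide-type nitrogen, so it gives no direct guide to the size or direction of this change. Replacing one five-membered aromatic ring by another that carries one more ring hetero atom is a small alteration, so the expectation is for a number close to that of compound 1 or somewhat higher. The estimate for compound 3 in this assay is 20 nM, with a range from 5 nM to 80 nM. Expressed as a step, this expected value means a 2.5-fold higher number from compound 1 to compound 3 (0.40 log units; beyond the scatter).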

Compound 3, half-maximal effective concentration: 3060 nM
For compound 3 the middle estimate is 150-fold (2.18 log units) below the measured one; measured number above the stated range.
By their numbers in this assay, from the lowest: compound 1; then compound 2; then compound 3.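

The place on the saturated chain carbon bound to an amide-type nitrogen proves highly sensitive to this change. In this assay, 1,3-thiazol-2-yl in place of thiophen-2-yl gives a 380-fold higher number from compound 1 to compound 3 (2.58 log units; beyond the scatter) even though both groups have 5 heavy atoms and the count differs only by one nitrogen in place of one carbon. That step is much larger than a 4.9-fold higher number from compound 1 to compound 2 (0.69 log units; beyond the scatter) and shows that a swap between two similar five-membered aromatic rings can change the number far more than the earlier change of chloro for methyl on an aromatic carbon. Nothing available explains the size of this step.

The compounds shown leave open whether other rings at this place, such as phenyl or furan-2-yl, would stay close to compound 1 or also give much higher numbers. They also leave open whether chloro in place of methyl on an aromatic carbon would have a similar effect in a compound carrying 1,3-thiazol-2-yl rather than thiophen-2-yl.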